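Aryl Urea Variation on a Cyclohexyl Ether Scaffold

This account rests on a few compounds, and the source may have more. Where it says the series, first, only, none or still open, it means among the compounds named here.

In a functional assay on CRL2813 cells (Homo sapiens) for cytotoxicity, read by sulforhodamine B assay, with a stated time of 5 days (on this read-out lower numbers stand for stronger inhibition and higher numbers for weaker inhibition), the measured compounds stand as follows:
compound 1 `O=C(Nc1cccc(F)c1)N[C@H]1CC[C@H](Oc2ccc(F)cc2)CC1` gives 8300 nM
compound 2 `O=C(Nc1ccc([N+](=O)[O-])cc1)N[C@H]1CC[C@H](Oc2ccc(F)cc2)CC1` gives 2300 nM
compound 3 `Cc1cccc(NC(=O)N[C@H]2CC[C@H](Oc3ccc(F)cc3)CC2)c1` gives 14400 nM

Compound 3 has the highest number of the three: a 1.7-fold higher number from compound 1 to compound 3 (0.24 log units; within the scatter) lies within the scatter, while a 6.3-fold higher number from compound 2 to compound 3 (0.80 log units; beyond the scatter) lies beyond it. Compound 4 `O=C(Nc1ccccc1Cl)N[C@H]1CC[C@H](Oc2ccc(F)cc2)CC1` differs from compound 3 by 2-chlorophenyl in place of 3-methylphenyl on an amide-type nitrogen. Going by the values given here, the steps that bear on this are the exchanges of the aryl group on that nitrogen: a 3.6-fold lower number from compound 1 to compound 2 (0.56 log units; beyond the scatter) and a 6.3-fold higher number from compound 2 to compound 3 (0.80 log units; beyond the scatter), both beyond the scatter, and a 1.7-fold higher number from compound 1 to compound 3 (0.24 log units; within the scatter), within it. Since a halogen on that ring in compound 1 changed little against methyl, compound 4 is expected to show a 1.6-fold lower number from compound 3 to compound 4 (0.20 log units; within the scatter), a modest lowering at most. The estimate for compound 4 is 9000 nM, within 3000 nM to 27000 nM.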

Compound 4, half-maximal inhibitory concentration: 9100 nM
Beside the measured number, compound 4's estimate is 1.0-fold (0.00 log units) below it; measured number inside the range.
By their numbers in this assay, from the lowest: compound 2; then compounds 1, 4 and 3 (each within the scatter of the next).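

In this assay, 2-chlorophenyl on the amide-type nitrogen falls in with the other two halogen- or methyl-bearing aryl groups: a 1.1-fold higher number from compound 1 to compound 4 (0.04 log units; within the scatter) and a 1.6-fold lower number from compound 3 to compound 4 (0.20 log units; within the scatter) are both within the scatter. With a 4.0-fold higher number from compound 2 to compound 4 (0.60 log units; beyond the scatter) beyond the scatter, compound 2 alone stands apart from the three others. No measurement given here explains this grouping. Going by these compounds, whether an aryl group carrying an amine or a carboxylic acid would fall with compound 2 or with the other three remains open, as does whether a non-aromatic group such as cyclohexyl on that nitrogen would keep this level of cytotoxicity.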